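Ester in place of hydroxyl on the side-chain amine

A few compounds are considered here, and "the series" means these few. Any claim that something is new, unique, unknown or untested is made for them only; others in the source may bear on it.

Measured compounds in this series:
compound 1 `CN(C)CCCNc1c(C(=O)NCc2ccc(F)cc2)nc(Br)c2cccnc12`: 7000 nM
compound 2 `O=C(NCc1ccc(F)cc1)c1nc(Br)c2cccnc2c1NCCO`: "not determined" (no result reported)
compound 3 `COC(=O)c1nc(Br)c2cccnc2c1N[C@H]1CC[C@H](N)CC1`: > 20000 nM

In a functional assay on MCF7 cells (Homo sapiens) for cytotoxicity, read by MTT assay, with a stated time of 72 h (a lower number here means a stronger inhibitor, a higher number a weaker inhibitor), compound 1 gives 7000 nM. For compound 2 the result reads "not determined" (no result reported), so no number stands for it. For compound 3 the value is a limit of the assay and not a number, > 20000 nM; this is the limit of > 20000 nM in this assay, at which 1 of the 3 values shown sits. Compound 2 therefore cannot be placed on the numbers shown; the two values that exist sit at a weak reading and at the upper limit.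

Compound 4 `COC(=O)CNc1c(C(=O)NCc2ccc(F)cc2)nc(Br)c2cccnc12` differs from compound 2 as follows: methoxycarbonyl in place of hydroxymethyl on a saturated chain carbon bound to a nitrogen on an aromatic ring. Methoxycarbonyl in place of hydroxymethyl on a saturated chain carbon bound to a nitrogen on an aromatic ring; read one bond further out, 2-hydroxyethyl becomes (methoxycarbonyl)methyl.

Going by the values given here, since compound 2 has no number, no step from compound 2 to compound 4 can be sized in this assay, in either direction. The shared core with a side-chain amine appears with a number once, compound 1 at 7000 nM, which is a weak reading. For compound 3 the same core gives only a limit of the assay in this assay. The expectation for compound 4 in this assay is therefore a weak reading, with a fair chance of a limit only.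

Compound 4 is expected to give about 12000 nM in this assay, estimated between 3000 nM and 40000 nM.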

Compound 4, half-maximal inhibitory concentration: > 10000 nM
Compound 4: only a limit was reported; the forecaster's own chance of this, stated with the estimate: 40%; the middle value is on the limit's open side.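

Compound 4 gives only a limit of the assay in this assay, so the (methoxycarbonyl)methyl group on the side-chain amine adds no number at this position: the limit of > 10000 nM in this assay, at which 1 of the 4 values shown sits. Setting methoxycarbonyl in place of 2-(dimethylamino)ethyl on a saturated chain carbon bound to a nitrogen on an aromatic ring gives an at least 1.4-fold higher number from compound 1 to compound 4 (0.15 log units; that floor lies within the scatter), so the change brings no gain over the side chain of compound 1, while any loss remains unsized. Compound 2 has no number, so the steps to it cannot be read, and the exchange of hydroxymethyl for methoxycarbonyl stays without a size in this series.

As far as these compounds go, how far the true reading of compound 4 lies beyond its limit remains open, and with it whether the change from the side chain of compound 1 costs anything real. Also open, from the compounds shown here alone, is whether a carboxylic acid in place of the methyl ester, or a longer chain ending in a primary amine, would give a number on this core in this assay.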